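The compounds below may be only part of what the source reports. "The series", "measured", "known", "first", "only" and "open" are said of these compounds alone.

Working notes on the series.

Compound 1 `O=C1OC(c2ccc(Cl)cc2)=C/C1=C\c1ccccc1` is the reference point. In a functional assay on the whole organism (strain Wistar) for inhibition, with Rattus norvegicus as the target, with stated times of 30 min and 3 h, at a dose of 20 mg/kg by the oral route (a lower number here means less inhibition, a higher number more inhibition at the dose given (going by the name of the read-out)), compound 1 gives 36%, the higher of the two numbers in hand. Going by the values given here, compound 2 `O=C1OC(c2ccc(Cl)cc2)=C/C1=C\c1ccccc1[N+](=O)[O-]` gives 18.5% in this assay; the only measured step, a number 17.5 percentage points lower from compound 1 to compound 2 (beyond the scatter), is therefore a drop beyond the scatter.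

Compound 3 `O=C1OC(c2ccc(Cl)cc2)=C/C1=C\c1ccc(F)cc1` has not been measured. It differs from compound 1 by fluoro in place of hydrogen on an aromatic carbon. Among the compounds with values here, the one step that bears on this is the nitro step, since it also puts a single group on an aromatic carbon of the same ring, and it lowered the number by a modest amount. Fluoro is a different group at a different place on that ring, so the nitro result is only a loose guide. The expected step of a number 6 percentage points lower from compound 1 to compound 3 (within the scatter) is small and slightly downward, possibly within the scatter. For compound 3 the estimate in this assay is 30%, with a range of 15% to 45%.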

Compound 3, a percentage reported as inhibition, in the whole organism at one dose (the size of the read-out at that dose, not a potency): 70.4%
For compound 3 the middle estimate is 40.4 percentage points below the measured one; the measured number lies above the stated range.
By their numbers in this assay, from the lowest: compound 2; then compound 1; then compound 3.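

In this assay the step of a number 34.4 percentage points higher from compound 1 to compound 3 (beyond the scatter) shows that this ring can gain as well as lose: a single fluoro, para to a large group, raises the number by a large amount. The step of a number 17.5 percentage points lower from compound 1 to compound 2 (beyond the scatter) went the other way with nitro, but the two changes differ in both group and place, and these data do not separate the two. No measurement in hand accounts for the rise.

Open is whether the gain belongs to fluoro itself or to that place on the ring, as no compound shown carries fluoro elsewhere on it. Also open, from the compounds shown here alone, is how a methoxy group or an amine at the same carbon would compare with fluoro in this assay and whether either would keep the gain.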